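The compounds below may be only part of what the source reports. "The series", "measured", "known", "first", "only" and "open" are said of these compounds alone.

Compound 1 `C[C@@H](Oc1cc(C(=O)N(C)C)ccc1Nc1nc(O[C@H]2CC[C@@](C)(O)CC2)c2cc[nH]c2n1)C(F)(F)F`: 15600 ng.h/mL
Compound 2 `COc1cc(N2CCC(C)(O)CC2)ccc1Nc1nc(O[C@H]2CCOC(C)(C)C2)c2cc[nH]c2n1`: 5300 ng.h/mL

In an ADME assay on the whole organism (Rattus norvegicus) for pharmacokinetics, at a dose of 10 mg/kg by the oral route (a higher number here means more compound in the circulation at the dose given, a lower number less compound in the circulation), compound 2 stands lower of the two at 5300 ng.h/mL and lies beyond the usual scatter from compound 1. Compound 3 `COc1cc(N2CCN(C(=O)CO)CC2)ccc1Nc1nc(O[C@H]2CCOC(C)(C)C2)c2cc[nH]c2n1` has not yet been measured. It differs from compound 2 in one place, with 4-((hydroxymethyl)carbonyl)piperazin-1-yl in place of 4-hydroxy-4-methylpiperidin-1-yl on an aromatic carbon and nothing else altered. Within the data shown here, no measured pair shows such a swap, so the expectation is loose: a modest fall, with the estimated step of a 2.1-fold lower number from compound 2 to compound 3 (0.33 log units; beyond the scatter) lying near the edge of the scatter. Compound 3 is estimated at 2500 ng.h/mL with 700 ng.h/mL to 8000 ng.h/mL as its expected range.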

Compound 3, area under the concentration-time curve: 4850 ng.h/mL
Estimate against measurement, compound 3: 1.9-fold (0.29 log units) below, and the stated range covers the measured number.
By their numbers in this assay, from the lowest: compounds 3 and 2 (each within the scatter of the next); then compound 1.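

Swapping 4-hydroxy-4-methylpiperidin-1-yl for 4-((hydroxymethyl)carbonyl)piperazin-1-yl on this aromatic carbon gives a 1.1-fold lower number from compound 2 to compound 3 (0.04 log units; within the scatter) in this assay and so leaves the two compounds indistinguishable. This position therefore accepts the larger group, with its second ring nitrogen and its carbonyl, without a measurable cost to the number. Nothing measured here bears on the reason for this result.

Still open, on these data alone, is whether a piperazine with a free amine, or a piperidine carrying a carboxylic acid, would read alike at this position.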